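Replacing a Hexyl Chain with a Methoxyphenyl Ring

The source may report more compounds than this note shows. Statements on the series, on what has been measured and on what is new or still open speak of the compounds shown alone.

In a functional assay on HeLa cells (Homo sapiens) for cytotoxicity, read by WST assay, with a stated time of 48 h (on this read-out higher numbers stand for weaker inhibition and lower numbers for stronger inhibition), compound 1 (`CCCCCC/C=C/C[C@H]1C[C@@H]([C@@H](O)c2ccccc2)CO[C@@H]1c1ccccc1`) gives 7400 nM. That value lies within the usual scatter of compound 3 (`COc1ccc(/C=C/C[C@H]2C[C@@H]([C@@H](O)c3ccc(OC)c(OC)c3)CO[C@@H]2c2ccc(OC)c(OC)c2)cc1`) at 12200 nM, while compound 2 (`COc1ccc(/C=C/C[C@@H]2C[C@@H]([C@@H](O)c3ccc(OC)c(OC)c3)CO[C@H]2c2ccc(OC)c(OC)c2)cc1`) at 17100 nM reads higher, beyond the scatter.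

Compound 4 (`COc1cccc(/C=C/C[C@H]2C[C@@H]([C@@H](O)c3ccccc3)CO[C@@H]2c2ccccc2)c1`) has 3-methoxyphenyl in place of hexyl on a double-bonded chain carbon bound to a double-bonded chain carbon.

Among the compounds with values here, no measured step makes this swap. Within the data shown here, the one measured step, a 1.4-fold lower number from compound 2 to compound 3 (0.15 log units; within the scatter), concerns the fact that compounds 2 and 3 differ only in the configuration as drawn and leaves the group in question untouched. Compounds 2 and 3 do hold a methoxy-bearing aromatic ring there, though they also differ from compound 1 elsewhere. Compound 2 gives 17100 nM and compound 3 gives 12200 nM, so only a modest upward shift is expected in this assay. The expected change is a 1.4-fold higher number from compound 1 to compound 4 (0.13 log units; within the scatter), which stays within the scatter. For compound 4 the estimated value is 10000 nM, with an expected range from 4000 nM to 25000 nM.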

Compound 4, half-maximal inhibitory concentration: 10900 nM
Beside the measured number, compound 4's estimate is 1.1-fold (0.04 log units) below it, within the range that was stated.
By their numbers in this assay, from the lowest: compounds 1, 4, 3 and 2 (each within the scatter of the next, the first and the last beyond it).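

In this assay the exchange of hexyl for 3-methoxyphenyl gives a 1.5-fold higher number from compound 1 to compound 4 (0.17 log units; within the scatter) and so tests this one place alone, whereas compounds 2 and 3 also differ from compound 1 elsewhere. At this double-bonded chain carbon, an open hexyl chain and an aromatic ring carrying a hydrogen-bond acceptor therefore read alike, and this single exchange moves the number by no more than the usual scatter. The information available offers no explanation for this result.

The compounds shown leave open whether a plain phenyl ring, an amine or a carboxylic acid at this place would also read alike. They also leave open whether a longer chain than hexyl would change the number on the core of compound 1.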